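The source may hold more compounds than are shown below. What is called first, only, known or untested is meant among the compounds shown, and "the series" means these compounds.

Compound 1 `COc1ccc(C=C2C(=O)N(c3ccc(Cl)cc3)N(c3ccc(Cl)cc3)C2=O)cc1`: > 128000 nM
Compound 2 `COc1ccc(C=C2C(=O)N(c3ccc(Cl)cc3)N(c3ccc(Cl)cc3)C2=O)cc1OC`: > 128000 nM

In a functional assay on ECa-109 cells (Homo sapiens) for cytotoxicity, read by MTT assay, with a stated time of 72 h (on this read-out higher numbers stand for weaker inhibition and lower numbers for stronger inhibition), compound 2 gives > 128000 nM, which is a limit and not a number. Compound 1 gives > 128000 nM, also a limit. Compound 3 `O=C1C(=C/C=C/c2ccccc2)C(=O)N(c2ccc(Cl)cc2)N1c1ccc(Cl)cc1` carries 2-phenylethenyl in place of 3,4-dimethoxyphenyl on a double-bonded chain carbon bound to a double-bonded ring carbon. Going by the values given here, the only measured step that bears on this change is a step that the two limits leave unreadable from compound 1 to compound 2, and its size cannot be read. Both values sit at the limit of > 128000 nM in this assay, at which 2 of the 2 values shown sit, so only a modest expected move toward stronger inhibition in this assay can be proposed, and compound 3 may well stay at the limit. The estimated step is an at least 1.8-fold lower number from compound 2 to compound 3 (0.26 log units; that floor lies within the scatter). For compound 3 the expected value is 70000 nM, with an estimated range of 15000 nM to 128000 nM.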

Compound 3, half-maximal inhibitory concentration: 9900 nM
Compound 3: the middle estimate sits 7.1-fold (0.85 log units) above what was measured, and the stated range ends above it.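

In this assay, this place gives its first readable change with 2-phenylethenyl in place of 3,4-dimethoxyphenyl: an at least 12-fold lower number from compound 2 to compound 3 (1.11 log units; beyond the scatter). With 2-phenylethenyl in place of 4-methoxyphenyl, the result is an at least 12-fold lower number from compound 1 to compound 3 (1.11 log units; beyond the scatter). The step between compound 1 and compound 2 cannot be read, because both values are limits: the limit of > 128000 nM in this assay, at which 2 of the 3 values shown sit.

The compounds shown do not separate the extra chain double bond from the loss of the methoxy groups, and a plain phenyl at this place would bear on that. On these data alone, how an amine on the ring of 2-phenylethenyl or a longer chain would read also stays open.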